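Hydroxymethyl in place of vinyl on the sulfonyl chain

This account rests on a few compounds, and the source may have more. Where it says the series, first, only, none or still open, it means among the compounds named here.

In a functional assay, read by fluorescence and spectrophotometry, with a stated time of 1 h (a lower number here means that less compound is needed, a higher number that more compound is needed for the effect), compound 1 (`C=CCCCCCCCS(=O)(=O)/C=C/c1ccc(O)c(O)c1`) gives 6900 nM as its half-maximal effective concentration, while compound 2 (`O=S(=O)(/C=C/c1ccc(O)c(O)c1)CC1CCC1`) gives 8800 nM and compound 3 (`O=S(=O)(/C=C/c1ccc(O)c(O)c1)CC1CCCN1`) gives 13800 nM on the same read-out. Compound 1 therefore stands within the scatter of both other compounds, and the three values do not separate.

Compound 4 (`O=S(=O)(/C=C/c1ccc(O)c(O)c1)CCCCCCCCO`) keeps the core of compound 1 and differs from it in one place (hydroxymethyl in place of vinyl on a saturated chain carbon, seven bonds along the chain from a sulfonyl sulfur): hydroxymethyl in place of vinyl on a saturated chain carbon, seven bonds along the chain from a sulfonyl sulfur.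

For the measured compounds named here, only one measured step is available (a 1.6-fold higher number from compound 2 to compound 3 (0.20 log units; within the scatter)). It puts pyrrolidin-2-yl in place of cyclobutyl on a saturated chain carbon bound to a sulfonyl sulfur, and it lies within the scatter. Going by the values given here, this is a different exchange at a different place, so it bears on compound 4 only indirectly, and no measured pair tests vinyl against hydroxymethyl. Neither that step nor the spread of the three values points to a large change, so in this assay no step beyond the scatter is expected. The estimated step is a 1.3-fold higher number from compound 1 to compound 4 (0.12 log units; within the scatter) and carries little weight in its direction. The estimated value of compound 4 is 9000 nM with an expected range of 4000 nM to 20000 nM in this series.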

Compound 4, half-maximal effective concentration: 6700 nM
The estimate for compound 4 lay 1.3-fold (0.13 log units) above the measured number; measured number inside the range.
By their numbers in this assay, from the lowest: compounds 4, 1, 2 and 3 (each within the scatter of the next, the first and the last beyond it).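

In this assay, hydroxymethyl in place of vinyl on a saturated chain carbon, seven bonds along the chain from a sulfonyl sulfur, gives a 1.0-fold lower number from compound 1 to compound 4 (0.01 log units; within the scatter), so this pair shows no step beyond the scatter at this place. The exchange removes a group with a double bond and no hydrogen-bond donor or acceptor and brings in one with 1 hydrogen-bond donor and 1 hydrogen-bond acceptor, and that difference in counts does not separate the two compounds on this read-out. The earlier step, a 1.6-fold higher number from compound 2 to compound 3 (0.20 log units; within the scatter), concerned another place on the chain and could not show this; nothing at hand bears on why compound 1 and compound 4 read alike.

For the compounds shown here, whether an amine or a carboxylic acid at this same place would also stay within the scatter remains open, since hydroxymethyl and vinyl are the only two groups compared here. Also open, going by these compounds, is whether a longer chain carrying the same hydroxymethyl, or a change to the shared core, would move the number in this assay beyond the scatter.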